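Adding an amino group to compound 2

This account rests on a few compounds, and the source may have more. Where it says the series, first, only, none or still open, it means among the compounds named here.

Values in a functional assay on MCF7 cells (Homo sapiens) for cytotoxicity, read by MTT assay, with a stated time of 96 h (on this read-out higher numbers stand for weaker inhibition and lower numbers for stronger inhibition), are as follows:
- Compound 1 `COc1cc(C(=O)c2cn(-c3ccccc3)cc2-c2ccc(Br)cc2)cc(OC)c1OC` gives 340 nM
- Compound 2 `COc1cc(C(=O)c2cn(-c3ccccc3)cc2-c2ccccc2[N+](=O)[O-])cc(OC)c1OC` gives 49 nM
- Compound 3 `COc1cccc(-c2cn(-c3ccccc3)cc2C(=O)c2cc(OC)c(OC)c(OC)c2)c1` gives 180 nM

Compound 2 has the lowest number of the three, which here means the strongest inhibition. The two steps that set it apart are a 6.9-fold lower number from compound 1 to compound 2 (0.84 log units; beyond the scatter) and a 3.7-fold higher number from compound 2 to compound 3 (0.57 log units; beyond the scatter), both beyond the scatter.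

The next compound, compound 4 `COc1cc(C(=O)c2cn(-c3cccc(N)c3)cc2-c2ccccc2[N+](=O)[O-])cc(OC)c1OC`, differs from compound 2 in one place: amino in place of hydrogen on an aromatic carbon. In words, this is amino in place of hydrogen on an aromatic carbon, turning phenyl into 3-aminophenyl.

Among the compounds with values here, no measured step covers this change. All three steps swap a different aryl group, and the third, a 1.9-fold lower number from compound 1 to compound 3 (0.28 log units; within the scatter), stays within the scatter. They show how far the numbers moved at that other place, but they give neither a direction nor a size for the new amino group. With nothing measured at this place, no step beyond the scatter is expected in this assay, although the uncertainty is wide. The estimate is a 1.4-fold lower number from compound 2 to compound 4 (0.15 log units; within the scatter), a small expected change. Compound 4 is expected at 35 nM, within a range of 10 nM to 150 nM until it is measured.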

Compound 4, half-maximal inhibitory concentration: 14 nM
Compound 4: middle estimate off by 2.5-fold (0.40 log units), on the high side, within the range that was stated.
By their numbers in this assay, from the lowest: compound 4; then compound 2; then compounds 3 and 1 (each within the scatter of the next).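

In this assay, the phenyl group shared by compound 1, compound 2 and compound 3 proves to be a place where the number can move: turning it into 3-aminophenyl gives a 3.5-fold lower number from compound 2 to compound 4 (0.54 log units; beyond the scatter). Within the data shown here, this is the first measured change at this place, and it shows that the numbers respond to more than the aryl group swapped among the earlier compounds. The step runs towards stronger inhibition and gives compound 4 the lowest number of the four, although the change adds only one heavy atom, yet nothing at hand explains the shift.

As far as these compounds go, it remains open whether the gain is specific to the amino group or would also appear with a hydroxyl, a methoxy or an acetamide at the same place. From the compounds shown here alone, it is equally open whether the amino group would shift the number by a similar amount when the 2-nitrophenyl group is replaced by the 3-methoxyphenyl group of compound 3 or the 4-bromophenyl group of compound 1.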